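Indole Amide to Cinnamamide: Expected Cytotoxicity Shift

The source may report more compounds than this note shows. Statements on the series, on what has been measured and on what is new or still open speak of the compounds shown alone.

Compound 2 `CCCCCCCCCCCCNC(=O)[C@@H](NC(=O)c1cc2ccccc2n1C)[C@@H](C)O` gives, in a functional assay on SiHa cells (Homo sapiens) for cytotoxicity, read by MTT assay, with a stated time of 48 h (a lower number here means a stronger inhibitor, a higher number a weaker inhibitor), only a limit, > 200000 nM, as shown by the limit of > 200000 nM in this assay, at which 1 of the 2 values shown sits. Its closest measured relative, compound 1 `CCCCCCCCCCCCNC(=O)[C@@H](NC(=O)c1nccc2ccccc12)[C@@H](C)O`, differs only in the group on the carbonyl carbon and gives 56600 nM in this assay. Among the compounds with values here, the single measured step, an at least 3.5-fold higher number from compound 1 to compound 2 (0.54 log units; beyond the scatter), is the only guide here. Compound 3 `CCCCCCCCCCCCNC(=O)[C@@H](NC(=O)/C=C/c1ccccc1)[C@@H](C)O` carries the change (2-phenylethenyl in place of 1-methyl-1H-indol-2-yl on a carbonyl carbon). Compound 2 sits at a limit, and the size of the step to compound 3 cannot be fixed from the data. The expected step of an at least 2.2-fold lower number from compound 2 to compound 3 (0.34 log units; beyond the scatter) is a modest return toward measurable weak inhibition. Compound 3 is estimated at 90000 nM, between 30000 nM and 300000 nM.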

Compound 3, half-maximal inhibitory concentration: > 200000 nM
Compound 3: only a limit was reported (the forecaster's own chance of this, stated with the estimate: 45%); middle value at least 2.2-fold (0.34 log units) away from the limit.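

Swapping isoquinolin-1-yl for 2-phenylethenyl on the carbonyl carbon gives an at least 3.5-fold higher number from compound 1 to compound 3 (0.54 log units; beyond the scatter). Of the three groups shown at this place, only isoquinolin-1-yl gives a measurable number in this assay. Compound 3 also ends at a limit rather than a number, the same one as compound 2: the limit of > 200000 nM in this assay, at which 2 of the 3 values shown sit.

The step between compound 2 and compound 3 cannot be read, as both results are limits. From the compounds shown here alone, whether a plain phenyl or a pyridin-2-yl group on the carbonyl carbon would give a measurable number stays open.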